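This account rests on a few compounds, and the source may have more. Where it says the series, first, only, none or still open, it means among the compounds named here.

Going by the values given here, only two compounds have been tested so far in a functional assay for inhibition, read by fluorescence and spectrophotometry, with a stated time of 30 h; on this read-out lower numbers stand for stronger inhibition and higher numbers for weaker inhibition. Compound 1 (`COc1ccc(-c2cc(=O)c3ccc(O)cc3o2)cc1OC`) gives 47400 nM, and compound 2 (`COc1ccc(-c2cc(=O)c3ccc(OCCCCN4CCC(C)CC4)cc3o2)cc1`) gives 48200 nM. These two numbers lie within the usual scatter of each other, so compound 2 stands level with compound 1. The next compound, compound 3 (`COc1ccc(-c2cc(=O)c3ccc(OCCCCCN4CCC(CCO)CC4)cc3o2)cc1`), differs from compound 2 on a saturated chain carbon, four bonds along the chain from an oxygen on an aromatic ring: (4-(2-hydroxyethyl)piperidin-1-yl)methyl in place of 4-methylpiperidin-1-yl on a saturated chain carbon, four bonds along the chain from an oxygen on an aromatic ring. Among the compounds with values here, no tested pair shows what such a change does in this assay, so the expectation starts from compound 2 at 48200 nM, and no change beyond the scatter is expected. The estimated step of a 1.4-fold lower number from compound 2 to compound 3 (0.14 log units; within the scatter) is therefore small. For compound 3 the expected value is 35000 nM, with an estimated range of 10000 nM to 100000 nM.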

Compound 3, half-maximal inhibitory concentration: 49400 nM
For compound 3 the middle estimate is 1.4-fold (0.15 log units) below the measured one; low and high end bracket the measured number.
By their numbers in this assay, from the lowest: compounds 1, 2 and 3 (each within the scatter of the next).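

Placing (4-(2-hydroxyethyl)piperidin-1-yl)methyl in the spot held by 4-methylpiperidin-1-yl gives a 1.0-fold higher number from compound 2 to compound 3 (0.01 log units; within the scatter) in this assay and leaves the two compounds level. Going by these compounds alone, this is the first pair here that differs in one place, and it shows that this saturated chain carbon can carry the larger group, with its added hydrogen-bond donor, without a step beyond the scatter. No available measurement explains this result.

Going by these compounds, the step brings in the extra methyl and the 2-hydroxyethyl together, so what each does alone stays open. Also open, on these data alone, is whether a primary amine or a carboxylic acid in place of the hydroxyl, or a longer chain, would give a number beyond the scatter of compound 2.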